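A few compounds are considered here, and "the series" means these few. Any claim that something is new, unique, unknown or untested is made for them only; others in the source may bear on it.

Measured so far in an ADME assay on SNB-19 cells (Homo sapiens) for cytotoxicity, read by MTT assay, with a stated time of 24 h; on this read-out lower numbers stand for higher toxicity in this test and higher numbers for lower toxicity in this test:
- compound 1 `C=C1CC[C@@H]2[C@](C)(COC(C)=O)[C@H](O)CC[C@@]2(C)[C@@H]1C/C=C1/C(=O)OC[C@@H]1Oc1cccc2ccc(C)nc12` gives 65900 nM
- compound 2 `C=C1CC[C@H]2[C@@](C)(CCC(=O)[C@@]2(C)COC(C)=O)[C@@H]1C/C=C1/C(=O)OC[C@@H]1Oc1cccc2ccc(C)nc12` gives 51700 nM
- compound 3 `C=C1CC[C@H]2[C@@](C)(CCC(=O)[C@@]2(C)COC(C)=O)[C@@H]1C/C=C1/C(=O)OC[C@H]1Oc1cccc2ccc(C)nc12` gives only a limit, > 100000 nM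

Compound 2 and compound 1 sit within the scatter of each other in this assay, so neither is set apart from the other; the third value is a limit and not a number. Among the measured compounds shown here, the only step measured within one change is an at least 1.9-fold higher number from compound 2 to compound 3 (0.28 log units; that floor lies within the scatter), a change of configuration at a saturated ring carbon and nothing on the aromatic ring; the floor of that step lies within the scatter, so even it shows no firm shift.

Compound 4 `C=C1CC[C@H]2[C@@](C)(CCC(=O)[C@@]2(C)COC(C)=O)[C@@H]1C/C=C1/C(=O)OC[C@@H]1Oc1cccc2cccnc12` is the next compound. It differs from compound 2 by hydrogen in place of methyl on an aromatic carbon: 2-methylquinolin-8-yl becomes quinolin-8-yl. For the measured compounds named here, no measured step here touches a substituent on that ring, so no direction can be drawn from the series; the expectation is a step that stays within the scatter, a 1.1-fold higher number from compound 2 to compound 4 (0.03 log units; within the scatter). Compound 4 is therefore estimated at 55000 nM, with a range from 25000 nM to 120000 nM, in this assay.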

Compound 4, half-maximal cytotoxic concentration: 21900 nM
Compound 4: the middle estimate sits 2.5-fold (0.40 log units) above what was measured; measured number outside the range, below it.
By their numbers in this assay, from the lowest: compound 4; then compounds 2 and 1 (each within the scatter of the next). At a limit, above all of these: compound 3.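

In this assay, among the compounds shown here, hydrogen in place of methyl on the aromatic carbon next to the ring nitrogen gives a 2.4-fold lower number from compound 2 to compound 4 (0.37 log units; beyond the scatter), the first step that touches the aromatic ring and the first that lies beyond the scatter. The position on the 2-methylquinolin-8-yl group therefore bears on this read-out: the quinolin-8-yl group of compound 4 goes with a modest move towards higher toxicity in this test. Nothing at hand bears on why the loss of this methyl has that effect.

A single step at one position leaves open what an ethyl group, a chlorine atom or an amine on the same carbon would give. Also open, from the compounds shown here alone, is whether the same change gives a similar step on the core of compound 1 or with the configuration of compound 3.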